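The source may report more compounds than this note shows. Statements on the series, on what has been measured and on what is new or still open speak of the compounds shown alone.

In a functional assay on the whole organism (Peritoneal cavity) with Rattus norvegicus as the target (on this read-out lower numbers stand for an effect already at smaller amounts and higher numbers for an effect only at larger amounts of compound), compound 1 (`CC(C)c1ccc2c(c1)c(SC(C)(C)C)c(CC(C)(C)CN(O)C(N)=O)n2Cc1ccc(Cl)cc1`) gives 46 umol/kg, compound 2 (`CC(C)(/C=N/OCC(=O)O)Cc1c(SC(C)(C)C)c2cc(OCc3cscn3)ccc2n1Cc1ccc(Cl)cc1`) gives 4.4 umol/kg, and compound 3 (`CC(C)(/C=N/OCC(=O)O)Cc1c(SC(C)(C)C)c2cc(OCc3ccccn3)ccc2n1Cc1ccc(Cl)cc1`) gives 0.12 umol/kg, the lowest number of the three. Compound 4 (`CC(C)c1ccc2c(c1)c(SC(C)(C)C)c(CC(C)(C)/C=N/OCC(=O)O)n2Cc1ccc(Cl)cc1`) differs from compound 3 in one place: isopropyl in place of (pyridin-2-yl)methoxy on an aromatic carbon. In words, this is isopropyl in place of (pyridin-2-yl)methoxy on an aromatic carbon, so the whole group leaves, ring included.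

Within the data shown here, one measured step bears on this place. In a 37-fold lower number from compound 2 to compound 3 (1.56 log units; beyond the scatter), only the ring of that group changes, pyridin-2-yl in place of 1,3-thiazol-4-yl, and the step is large and beyond the scatter. The number therefore responds strongly to this group, and losing it altogether could cost much of what compound 3 shows at 0.12 umol/kg. Compound 1 also carries isopropyl and gives 46 umol/kg, but its side chain differs, so it is only a loose guide. A large move to a higher number is expected, beyond the scatter, and the estimated step is a 25-fold higher number from compound 3 to compound 4 (1.40 log units; beyond the scatter). The estimate for compound 4 is 3 umol/kg, with an expected range from 0.5 umol/kg to 20 umol/kg.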

Compound 4, dose for half-maximal effect: 3 umol/kg
For compound 4 middle estimate and measured number coincide at the digits printed; the measured number falls inside the stated range.
By their numbers in this assay, from the lowest: compound 3; then compounds 4 and 2 (each within the scatter of the next); then compound 1.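

In this assay there is a 25-fold higher number from compound 3 to compound 4 (1.40 log units; beyond the scatter) when isopropyl replaces (pyridin-2-yl)methoxy, so the low number of compound 3 is tied to that group at this aromatic carbon. Isopropyl and (1,3-thiazol-4-yl)methoxy cannot be told apart, with a 1.5-fold lower number from compound 2 to compound 4 (0.17 log units; within the scatter) between them, so carrying a ring on this oxygen-linked group is not enough on its own, and compound 2 goes against any such rule. With isopropyl on both compounds, a change of side chain alone gives a 15-fold lower number from compound 1 to compound 4 (1.19 log units; beyond the scatter) and shows that this second place also moves the number strongly.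

No measurement given here explains why these groups differ. Going by these compounds, it remains open whether benzyloxy, which has a phenyl ring in place of the pyridine, or plain methoxy would keep the low number of compound 3.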